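Trifluoromethyl in place of methyl: a stability estimate

This account rests on a few compounds, and the source may have more. Where it says the series, first, only, none or still open, it means among the compounds named here.

Compound 1 (`CCCCCCNc1ccc(C(=O)O)cc1S(N)(=O)=O`): > 1 h (a limit of the assay)
Compound 2 (`CCCCCCNc1ccc(C(=O)O)cc1S(=O)(=O)N(C)C`): 0.283 h

In an ADME assay on microsomes from liver (Mus musculus) for metabolic stability, tested at 5 uM (a lower number here means that the compound disappears faster, a higher number that the compound lasts longer), compound 1 reaches only a limit of the assay (> 1 h). Within the data shown here, compound 2 gives the only exact number so far (0.283 h). Among the measured compounds shown here, the one measured step (an at least 3.5-fold lower number from compound 1 to compound 2 (0.54 log units; beyond the scatter)) lies beyond the scatter and leaves compound 2 as the lower of the pair.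

Compound 3 (`CN(C)S(=O)(=O)c1cc(C(=O)O)ccc1NCCCCCC(F)(F)F`) keeps the rest of compound 2 and alters only the chain (trifluoromethyl in place of methyl on a saturated chain carbon, five bonds along the chain from a nitrogen on an aromatic ring). This places trifluoromethyl in place of methyl on a saturated chain carbon, five bonds along the chain from a nitrogen on an aromatic ring.

For the measured compounds named here, the one measured step was made at a sulfonyl sulfur, so no measurement tests this change directly. Its size (an at least 3.5-fold lower number from compound 1 to compound 2 (0.54 log units; beyond the scatter)) serves only as a rough gauge. A modest rise is expected in this assay, though it may stay within the scatter. The estimated step is (a 1.6-fold higher number from compound 2 to compound 3 (0.20 log units; within the scatter)). Compound 3 is expected at (0.45 h), with an estimated range from (0.2 h) to (1 h).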

Compound 3, half-life: > 1 h
Compound 3 ended at the assay's limit (the forecaster's own chance of this, stated with the estimate: 20%); middle value at least 2.2-fold (0.34 log units) away from the limit.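

In this assay, the change at this position gives an at least 3.5-fold higher number from compound 2 to compound 3 (0.54 log units; beyond the scatter), the first measured sign that the chain, and not only the sulfonyl sulfur, governs this read-out: trifluoromethyl in place of methyl on a saturated chain carbon, five bonds along the chain from a nitrogen on an aromatic ring, moves the number beyond the scatter. For compound 3, > 1 h is a limit of the assay, so this step marks only the least that the change achieves and gives no exact half-life. How much further the true value lies cannot be read from these compounds, and compound 3 cannot be ranked against compound 1, as both stop at the same ceiling: the limit of > 1 h in this assay, at which 2 of the 3 values shown sit.

Going by these compounds, it remains open whether a single fluorine, a hydroxyl group or a nitrile at this chain end would raise the number as well, and whether a shorter or longer chain carrying trifluoromethyl would behave in the same way. On these data alone, it is also open whether the same change would hold with the amino group of compound 1 on the sulfonyl sulfur, or with an amide in place of the carboxylic acid.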